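The compounds below may be only part of what the source reports. "The series", "measured", "known", "first", "only" and "open" are said of these compounds alone.

Of the compounds shown here, three have so far been measured in an assay on isolated protein for inhibition of Dihydrofolate reductase (Homo sapiens), read by spectrophotometry, using NADPH, with stated times of 5 s and 6 min; a lower number here means a stronger inhibitor, a higher number a weaker inhibitor. Compound 1 `Cc1ccc(OCCCON2C(N)=NC(N)=NC23CCOCC3)cc1` gives 56.8 nM, the highest of the three numbers. Compound 2 `NC1=NC2(CCSCC2)N(OCCCOc2ccc(Cl)cc2)C(N)=N1` gives 18.3 nM, and compound 3 `NC1=NC2(CCSCC2)N(OCCCOc2ccc(Br)cc2)C(N)=N1` gives 6.46 nM. Going by the values given here, the only step between two compounds that differ in one place is a 2.8-fold lower number from compound 2 to compound 3 (0.45 log units; beyond the scatter). Compound 4 `COc1ccc(OCCCON2C(N)=NC(N)=NC23CCOCC3)cc1` is compound 1 with methoxy in place of methyl on an aromatic carbon. Among the compounds with values here, no measured step bears directly on this change: the step from chloro to bromo concerns a different group on a different core, so it gives no guide to exchanging methyl for methoxy. Compound 4 is therefore expected to stay within the scatter of compound 1 in this assay. The expected step is a 1.1-fold lower number from compound 1 to compound 4 (0.06 log units; within the scatter). Compound 4 is estimated at 50 nM, with a range from 20 nM to 140 nM.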

Compound 4, half-maximal inhibitory concentration: 11.1 nM
Compound 4: the middle estimate sits 4.5-fold (0.65 log units) above what was measured; measured number outside the range, below it.
By their numbers in this assay, from the lowest: compounds 3, 4 and 2 (each within the scatter of the next, the first and the last beyond it); then compound 1.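

In this assay there is a 5.1-fold lower number from compound 1 to compound 4 (0.71 log units; beyond the scatter) when methoxy replaces methyl, so this place on the aromatic ring, para to a large group, responds clearly to what it carries. This is the first change shown on the core of compound 1, and it adds one oxygen and one hydrogen-bond acceptor. No measurement here says why the number falls.

Going by these compounds, whether methoxy would give a similar step on the core of compound 2 remains open. So does how an ethoxy group or an amine at this place would compare.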